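The source may report more compounds than this note shows. Statements on the series, on what has been measured and on what is new or still open speak of the compounds shown alone.

Working notes on the series.

Compound 1 `O=C1/C(=C\c2cccnc2)c2ccccc2N1Cc1ccccc1` is the parent of the set. In a functional assay on HL-60 cells (Homo sapiens) for cytotoxicity, read by MTT assay, with a stated time of 72 h, tested at 1 uM (a lower number here means a stronger effect, a higher number a weaker effect of the compound at the concentration tested), compound 1 gives 93.2%. Compound 2 `CC(c1ccccc1)N1C(=O)/C(=C\c2cccnc2)c2ccccc21` carries the change methyl in place of hydrogen on a saturated chain carbon bound to an amide-type nitrogen in a ring and an aromatic carbon relative to compound 1, and in this assay compound 2 gives 88%. Among the compounds with values here, the step of a number 5.2 percentage points lower from compound 1 to compound 2 (within the scatter) is the only one measured for this change so far.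

Compound 3 `O=C1/C(=C\c2ccnc3ccccc23)c2ccccc2N1Cc1ccccc1` has a different core from compound 1; the difference between the two cores is not broken down here. In this assay compound 3 gives 85.2%. The three values of compounds 1, 2 and 3 lie within the scatter of one another, so no order among them is claimed.

Compound 4 `CC(c1ccccc1)N1C(=O)/C(=C\c2ccnc3ccccc23)c2ccccc21` is the unmeasured member. It differs from compound 3 by methyl in place of hydrogen on a saturated chain carbon bound to an amide-type nitrogen in a ring and an aromatic carbon, which is the same change as that made from compound 1 to compound 2, at a place described in the same words. What is expected for compound 4 rests on this single pairing: on the core of compound 1 the change gave a number 5.2 percentage points lower from compound 1 to compound 2 (within the scatter), a step that stayed within the scatter, and on the core of compound 3 a step of similar size is estimated, that is a number 4.2 percentage points lower from compound 3 to compound 4 (within the scatter). On these data alone, whether the change behaves the same way on the second core is untested, so the range is kept broad. For compound 4 the value in this assay is estimated at 81%, with a range from 70% to 92%.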

Compound 4, a percentage reported as activity, at one concentration (the size of the read-out at that concentration, not a potency): 72.6%
Compound 4: middle estimate off by 8.4 percentage points, on the high side, and the stated range covers the measured number.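

In this assay, the change from benzyl to 1-phenylethyl on the core of compound 3 gives a number 12.6 percentage points lower from compound 3 to compound 4 (beyond the scatter), and of the two steps for this change, only this one lies beyond the scatter. Set beside the earlier step, it gives no ground for saying that the change acts differently on the two cores, because the gap between the steps is no larger than two such steps can scatter: the same change on two cores in this assay, a number 5.2 percentage points lower (within the scatter) from compound 1 to compound 2 and a number 12.6 percentage points lower (beyond the scatter) from compound 3 to compound 4, 7.4 percentage points apart, within the scatter of two such steps. Within the data shown here, this does not show that the steps are equal or that the change carries over with a fixed size, since the comparison rests on only two pairs of compounds in one assay at a single concentration, and it says nothing about any further core.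

The compounds shown leave open whether a longer chain, such as ethyl in place of the methyl on the saturated chain carbon, would extend or reverse the step seen from compound 3 to compound 4. They also leave open how an amine or a carboxylic acid at that same carbon would read on either core.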